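Solubility of a Biaryl Analogue Within a Quinoline-Ether Series

The source may report more compounds than this note shows. Statements on the series, on what has been measured and on what is new or still open speak of the compounds shown alone.

Measured compounds:
Compound 1, `COc1ccc(Oc2ccc3c(NCCCNCc4cccc(OC)c4O)ccnc3c2)cc1`, 14500 nM
Compound 2, `COc1cccc(CNCCCNc2ccnc3cc(Cc4ccccc4)ccc23)c1O`, 4200 nM
Compound 3, `COc1cccc(CNCCCNc2ccnc3cc(Oc4ccc(F)cc4)ccc23)c1O`, 14500 nM

In a physicochemical assay for solubility, with a stated time of 18 h, at pH 7.4 (on this read-out lower numbers stand for lower solubility and higher numbers for higher solubility), compound 3 gives 14500 nM. On the numbers shown, compound 3 stands level with compound 1, and the two together hold the highest values of the three; the step of no change at the digits printed from compound 1 to compound 3 (within the scatter) is within the scatter, whereas a 3.5-fold higher number from compound 2 to compound 3 (0.54 log units; beyond the scatter) is beyond it.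

Compound 4, `COc1cccc(CNCCCNc2ccnc3cc(-c4ccc(C(F)(F)F)cc4)ccc23)c1O`, is not yet measured in this assay. It differs from compound 3 in one place: 4-(trifluoromethyl)phenyl in place of 4-fluorophenoxy on an aromatic carbon.

Among the measured compounds shown here, two measured steps bear on this. The exchange of fluoro for methoxy, no change at the digits printed from compound 1 to compound 3 (within the scatter), left the number unchanged. The exchange at the same aromatic carbon that replaced benzyl with 4-fluorophenoxy, a 3.5-fold higher number from compound 2 to compound 3 (0.54 log units; beyond the scatter), raised the number modestly. For the measured compounds named here, no measured step joins a phenoxy group directly to a phenyl group carried on the ring itself, so the expectation rests on the direction set by the benzyl-to-phenoxy comparison. A modest step downward from compound 3 to compound 4 is therefore expected, a 2.9-fold lower number from compound 3 to compound 4 (0.46 log units; beyond the scatter). Compound 4 is estimated at 5000 nM, within a range from 1500 nM to 15000 nM.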

Compound 4, solubility: 32000 nM
Beside the measured number, compound 4's estimate is 6.4-fold (0.81 log units) below it; the measured number lies above the stated range.
By their numbers in this assay, from the lowest: compound 2; then compounds 1 and 3 (each within the scatter of the next); then compound 4.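

In this assay, among the compounds shown here, the aromatic carbon that held the benzyl and phenoxy groups of the earlier compounds now carries a 4-(trifluoromethyl)phenyl group, and this gives the highest number of the series: a 2.2-fold higher number from compound 3 to compound 4 (0.34 log units; beyond the scatter), a 2.2-fold higher number from compound 1 to compound 4 (0.34 log units; beyond the scatter), and a 7.6-fold higher number from compound 2 to compound 4 (0.88 log units; beyond the scatter). The earlier compounds shown here showed a spread at this carbon only between benzyl and the two phenoxy groups, so the top of the range at this position is now higher than those groups suggested. An oxygen in the group is not needed for a high number here, since 4-(trifluoromethyl)phenyl has none, although the oxygen-free benzyl of compound 2 remains the lowest, so the absence of oxygen alone does not set the order, and nothing available here accounts for the rise.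

The compounds shown do not separate the part played by the direct attachment of the aromatic ring from the part played by the trifluoromethyl group, and a plain phenyl or a 4-fluorophenyl at this carbon would divide the two. From the compounds shown here alone, whether a ring carrying an amine or a carboxylic acid at the same place would continue the trend also stays open.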